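This account rests on a few compounds, and the source may have more. Where it says the series, first, only, none or still open, it means among the compounds named here.

Measured so far:
- Compound 1, `NC(=O)c1ccc(-c2cccnc2)cc1OC1CCNCC1`; in an assay on cells for inhibition of MAP kinase-interacting serine/threonine-protein kinase 1 (Homo sapiens), read by mobility shift assay, with stated times of 10 min and 60 min, in the presence of a further agent that is not named here (on this read-out higher numbers stand for weaker inhibition and lower numbers for stronger inhibition), compound 1 gives 1100 nM.
- Compound 2, `CCNc1cc(-c2cccnc2)ccc1C(N)=O`; in this assay compound 2 gives 58000 nM.

Among the compounds with values here, compound 2 stands as the highest of the two numbers measured so far; its only neighbour is compound 1, and the step of a 53-fold higher number from compound 1 to compound 2 (1.72 log units; beyond the scatter) lies well beyond the scatter. Within the data shown here, that single step is the one measured change, and it shows that the group on the aromatic carbon next to the carbamoyl position matters strongly.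

The next compound, compound 3, is `NCCOc1cc(-c2cccnc2)ccc1C(N)=O`. It differs from compound 2 by 2-aminoethoxy in place of ethylamino on an aromatic carbon. Among the measured compounds shown here, no measured step covers this exact exchange. For the measured compounds named here, the only step that bears on it is a 53-fold higher number from compound 1 to compound 2 (1.72 log units; beyond the scatter), which shows that a group carrying an ether oxygen and a basic nitrogen at this position gives a far lower number than ethylamino does. Compound 3 brings back both an oxygen link and a basic nitrogen, though on a shorter chain without a ring.

For that reason a marked downward step a 9.7-fold lower number from compound 2 to compound 3 (0.99 log units; beyond the scatter) is expected, though not necessarily all the way back to compound 1. Compound 3 is therefore estimated at 6000 nM, with a range of 1500 nM to 25000 nM.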

Compound 3, half-maximal inhibitory concentration: 820 nM
Compound 3: the middle estimate sits 7.3-fold (0.86 log units) above what was measured; measured number outside the range, below it.
By their numbers in this assay, from the lowest: compounds 3 and 1 (each within the scatter of the next); then compound 2.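

In this assay, the exchange of ethylamino for 2-aminoethoxy, ortho to a carbamoyl group, gives a 71-fold lower number from compound 2 to compound 3 (1.85 log units; beyond the scatter), so the large step seen earlier at this place does not depend on the piperidin-4-yl group of compound 1. On the same oxygen, 2-aminoethyl in place of piperidin-4-yl gives a 1.3-fold lower number from compound 1 to compound 3 (0.13 log units; within the scatter), so these two groups cannot be told apart in this read-out, and a ring on the oxygen is not required to reach this range in the compounds shown. No measurement at hand offers an explanation for either step.

Still open, from the compounds shown here alone, is which part of the exchange carries the large step, since ethylamino and 2-aminoethoxy differ both in the atom attached to the aromatic carbon and in the terminal amine; the pair ethoxy and 2-aminoethylamino would separate the two. Also open, going by these compounds, is how far the chain on the oxygen can change, for example to the longer 3-aminopropoxy or to a 2-(dimethylamino)ethoxy group with a tertiary amine at its end.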